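This account rests on a few compounds, and the source may have more. Where it says the series, first, only, none or still open, it means among the compounds named here.

Compound 2 `N#CC1=C(N)N(c2ccc(S(N)(=O)=O)cc2)C2=C(CCCC2)C1c1cccc([N+](=O)[O-])c1` gives 1% in a functional assay on Ehrlich cells (Mus musculus) for cytotoxicity, read by trypan blue exclusion, with a stated time of 2 h, tested at 25 ug/mL (a lower number here means a weaker effect, a higher number a stronger effect of the compound at the concentration tested), the lowest of the two numbers available; compound 1 `COc1ccccc1C1C(C#N)=C(N)N(c2ccc(S(N)(=O)=O)cc2)C2=C1CCCC2` gives 40% in this assay. Compound 3 `N#CC1=C(N)N(c2ccc(S(N)(=O)=O)cc2)C2=C(CCCC2)C1c1c(O)ccc2ccccc12` differs from compound 2 by 2-hydroxynaphthalen-1-yl in place of 3-nitrophenyl on a saturated ring carbon. Among the measured compounds shown here, the only measured step at this saturated ring carbon, a number 39 percentage points lower from compound 1 to compound 2 (beyond the scatter), shows that the group there can move the read-out by a large amount, and compound 1 carries 2-methoxyphenyl at that place. For the measured compounds named here, no step of exactly this kind has been measured, so the expectation is uncertain. Compound 3 is expected to give 25% (range 3% to 55%), an estimated step of a number 24 percentage points higher from compound 2 to compound 3 (beyond the scatter), beyond the scatter.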

Compound 3, a percentage reported as activity, at one concentration (the size of the read-out at that concentration, not a potency): 5%
Estimate against measurement, compound 3: 20 percentage points above; measured number inside the range.
By their numbers in this assay, from the lowest: compounds 2 and 3 (each within the scatter of the next); then compound 1.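

At the saturated ring carbon, 2-hydroxynaphthalen-1-yl in place of 3-nitrophenyl gives a number 4 percentage points higher from compound 2 to compound 3 (within the scatter) in this assay despite the differing aromatic ring and hydrogen-bond donor counts of these groups. The same group in place of 2-methoxyphenyl gives a number 35 percentage points lower from compound 1 to compound 3 (beyond the scatter) and so shows that the large change at this position is not confined to 3-nitrophenyl. No evidence here explains why compound 1 stands apart. The compounds shown leave open whether the read-out of compound 1 depends on its methoxy group or on where that group sits. They also leave open how an amine or a carboxylic acid on the aryl ring would read.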